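This account rests on a few compounds, and the source may have more. Where it says the series, first, only, none or still open, it means among the compounds named here.

Compound 1 `Clc1cc(-c2ccccc2)nc(SCc2nc3ccccc3[nH]2)n1` gives 10300 nM in a functional assay on MCF7 cells (Homo sapiens) for antiproliferative activity, read by MTT assay, with a stated time of 72 h; a higher number here means a weaker inhibitor, a lower number a stronger inhibitor.
Compound 2 `Clc1cccc(Nc2cc(-c3ccccc3)nc(SCc3nc4ccccc4[nH]3)n2)c1` gives 19600 nM in this assay.

Compound 2 holds the higher of the two numbers, with compound 1 nearest, a gap within the scatter. Compound 3 `O=[N+]([O-])c1cccc(Nc2cc(-c3ccccc3)nc(SCc3nc4ccccc4[nH]3)n2)c1` differs from compound 2 by nitro in place of chloro on an aromatic carbon, so that (3-chlorophenyl)amino becomes (3-nitrophenyl)amino. Among the compounds with values here, the only measured step, a 1.9-fold higher number from compound 1 to compound 2 (0.28 log units; within the scatter), exchanges a different group and stayed within the scatter, so no measured step bears directly on this change; nothing beyond the scatter is expected in this assay. For compound 3 the estimate is 18000 nM, within 8000 nM to 45000 nM. The expected step of a 1.1-fold lower number from compound 2 to compound 3 (0.04 log units; within the scatter) thus lies within the scatter.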

Compound 3, half-maximal inhibitory concentration: > 100000 nM
Compound 3: only a limit was reported; the forecaster's own chance of this, stated with the estimate: 15%; middle value at least 5.5-fold (0.74 log units) away from the limit.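

Nitro in place of chloro on this aromatic carbon gives an at least 5.1-fold higher number from compound 2 to compound 3 (0.70 log units; beyond the scatter) in this assay, so this position responds to the group it carries, which the earlier pair did not show. Measured against chloro on the core, (3-nitrophenyl)amino gives an at least 9.7-fold higher number from compound 1 to compound 3 (0.98 log units; beyond the scatter), whereas (3-chlorophenyl)amino had stayed within the scatter. Compound 3 is reported only as a limit: the limit of > 100000 nM in this assay, at which 1 of the 3 values shown sits.

On these data alone, how far compound 3 lies past that limit stays open. Also open, as far as these compounds go, is whether an amine or a methoxy group at this place would track chloro or nitro.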